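Arylamino versus cyclic amine at the quinone carbon

This account rests on a few compounds, and the source may have more. Where it says the series, first, only, none or still open, it means among the compounds named here.

Measured in a functional assay on HeLa cells (Homo sapiens) for inhibition, read by sulforhodamine B assay; a higher number here means a weaker inhibitor, a lower number a stronger inhibitor:
compound 1 `O=C1C(Nc2ccc(I)cc2)=CC(=O)c2c1nc1n2[C@H]2OC[C@@H](O)[C@H]2OC1` gives 4010 nM
compound 2 `O=C1C=C(N2CCC2)C(=O)c2c1nc1n2[C@H]2OC[C@@H](O)[C@H]2OC1` gives > 16000 nM, a limit of the assay
compound 3 `O=C1C(NC2CCCC2)=CC(=O)c2c1nc1n2[C@H]2OC[C@@H](O)[C@H]2OC1` gives > 16000 nM, a limit of the assay

Compound 2, bearing azetidin-1-yl, stands at the top of the range seen here: its result is only a limit, not a number, and this shared bound is the limit of > 16000 nM in this assay, at which 2 of the 3 values shown sit. Compound 1 alone yields a measured value. For the measured compounds named here, the one step with both ends measured, an at least 3.9-fold higher number from compound 1 to compound 3 (0.60 log units; beyond the scatter), goes from the 4-iodophenylamino compound to the cyclopentylamino one and ends at the same limit as compound 2, so in this small set only the arylamino compound gives a number in this assay.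

Compound 4 `COc1ccc(NC2=CC(=O)c3nc4n(c3C2=O)[C@H]2OC[C@@H](O)[C@H]2OC4)cc1` differs from compound 2 by (4-methoxyphenyl)amino in place of azetidin-1-yl on a double-bonded ring carbon. The entering group is of the same kind as the arylamino in compound 1, an anilino with a hydrogen-bond donor, while the leaving azetidin-1-yl has none. Nothing here separates methoxy from iodo on the ring, so the expected value for compound 4 is anchored to compound 1 with wide spread. The step of an at least 2.6-fold lower number from compound 2 to compound 4 (0.42 log units; beyond the scatter) is expected to bring compound 4 below the limit, though the outcome may remain a limit. Compound 4 is estimated at 6000 nM (range 2500 nM to 16000 nM).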

Compound 4, half-maximal inhibitory concentration: 4780 nM
Compound 4: the middle estimate sits 1.3-fold (0.10 log units) above what was measured; the range from low to high includes it.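

In this assay, (4-methoxyphenyl)amino in place of azetidin-1-yl on the double-bonded ring carbon gives an at least 3.3-fold lower number from compound 2 to compound 4 (0.52 log units; beyond the scatter), so a second arylamino compound now yields a number, while compound 2 and compound 3 remain limits of the assay. The anilino result therefore no longer rests on compound 1 alone: compound 1 gives 4010 nM and compound 4 gives 4780 nM, two values within the usual scatter of each other, so this pair shows no separation between 4-iodophenylamino and (4-methoxyphenyl)amino. The step size is only a lower bound because compound 2 has a limit and not a number: the limit of > 16000 nM in this assay, at which 2 of the 4 values shown sit.

The amine hydrogen alone does not account for the result, since cyclopentylamino also carries one and compound 3 is a limit, but these compounds do not separate the aromatic ring from the way it is attached, which an N-methylanilino or a benzylamino group at the same carbon would address. Also open, going by these compounds, is how far the ring substituent can vary before the value moves, for instance with a carboxylic acid or a dimethylamino group in place of iodo or methoxy.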